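A few compounds are considered here, and "the series" means these few. Any claim that something is new, unique, unknown or untested is made for them only; others in the source may bear on it.

Measured in an in vitro ADME assay on microsomes from liver (Homo sapiens) for metabolic stability, tested at 0.2 uM; a higher number here means faster removal of the compound, a lower number slower removal:
- Compound 1 `Cc1ccc2[nH]c(COc3cccc(OCC4CCOCC4)c3)c(C)c(=O)c2c1`: "not determined" (no result reported)
- Compound 2 `O=c1c(Cl)c(COc2cccc(OCC3CCOCC3)c2)[nH]c2ccccc12`: 460 mL/min/kg
- Compound 3 `COc1ccc2[nH]c(COc3cccc(OCC4CCOCC4)c3)c(C)c(=O)c2c1`: "not determined" (no result reported)

Among the measured compounds shown here, only one compound in this small set has a number. Compound 3 has no single value in this assay, and compound 1 is in the same position, so neither offers a starting point for comparison. For the measured compounds named here, no step between measured compounds is available either.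

Compound 4 `Cc1c(COc2cccc(OCC3CCOCC3)c2)[nH]c2ccc(-c3cccnc3)cc2c1=O` is derived from compound 3 by a single change, with pyridin-3-yl in place of methoxy on an aromatic carbon. The new group sits on a six-membered aromatic ring of carbon only, part of a fused system of two rings.

The expectation for compound 4 therefore rests on one reference, compound 2 at 460 mL/min/kg. Nothing in the data favours a direction, so no step beyond the usual scatter is expected from that level in this assay, though the uncertainty is wide. For compound 4 the estimated clearance is 320 mL/min/kg, with an expected range of 110 mL/min/kg to 800 mL/min/kg.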

Compound 4, clearance: 756 mL/min/kg
The estimate for compound 4 lay 2.4-fold (0.37 log units) below the measured number, within the range that was stated.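

Compound 4 gives 756 mL/min/kg in this assay, but compound 3 has no single number there, and no new step can be read. The compounds shown leave open how pyridin-3-yl in place of methoxy alters clearance. No supporting evidence bears on this result.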